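Swapping the methoxyphenyl arm for a diformylphenyl arm

The compounds below may be only part of what the source reports. "The series", "measured", "known", "first", "only" and "open" are said of these compounds alone.

Measured compounds:
compound 1, `COc1ccc(C=c2s/c(=C3\C(=O)Nc4cc(F)ccc43)n(CCN(C)C)c2=O)cc1`, 2200 nM
compound 2, `CCN(CC)CCCn1c(=O)c(=Cc2ccc(O)cc2)s/c1=C1\C(=O)Nc2ccc(C)cc21`, 260 nM
compound 3, `CCN(CC)CCCn1c(=O)c(=Cc2ccc(F)cc2F)s/c1=C1\C(=O)Nc2ccccc21`, 5470 nM

Of the compounds shown here, three share a core and have been tested in a functional assay on NCI-H460 cells (Homo sapiens) for inhibition, read by MTT assay, with a stated time of 72 h; a lower number here means a stronger inhibitor, a higher number a weaker inhibitor. Compound 1 stands second highest of the three: compound 3 sits above it, beyond the scatter, while compound 2 sits furthest below it, also beyond the scatter. Compound 4, `CN(C)CCn1c(=O)c(=Cc2ccc(C=O)c(C=O)c2)s/c1=C1\C(=O)Nc2cc(F)ccc21`, has not yet been measured. It differs from compound 1 in one place: 3,4-diformylphenyl in place of 4-methoxyphenyl on a double-bonded chain carbon bound to an aromatic carbon. Within the data shown here, no pair among the measured compounds shows this change, so its effect is unknown. A step of no clear size beyond the scatter is expected, a 1.1-fold higher number from compound 1 to compound 4 (0.06 log units; within the scatter). Compound 4 is estimated at 2500 nM, within 800 nM to 8000 nM.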

Compound 4, half-maximal inhibitory concentration: 2810 nM
Compound 4: the middle estimate sits 1.1-fold (0.05 log units) below what was measured; low and high end bracket the measured number.
By their numbers in this assay, from the lowest: compound 2; then compounds 1, 4 and 3 (each within the scatter of the next, the first and the last beyond it).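

Replacing 4-methoxyphenyl with 3,4-diformylphenyl on a double-bonded chain carbon bound to an aromatic carbon gives in this assay a 1.3-fold higher number from compound 1 to compound 4 (0.11 log units; within the scatter) and stays within the scatter. Among these compounds, this is the first single-place comparison at this position, and it shows that two formyl groups and a larger arm by heavy-atom count leave the two compounds indistinguishable here. No measurement shown accounts for this result. From the compounds shown here alone, what an amine or a carboxylic acid on this phenyl arm would give remains open. So does whether the same swap would read alike with a longer chain on the core.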